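This account rests on a few compounds, and the source may have more. Where it says the series, first, only, none or still open, it means among the compounds named here.

Measured compounds:
- compound 1, `COc1cc2cc(Oc3ccc(NC(=O)Nc4cccc(C(F)(F)F)c4)cc3)c(C)nc2cc1OC`: 2590 nM
- compound 2, `COc1cc2cc(Oc3ccc(NC(=O)Nc4ccc(Cl)c(C(F)(F)F)c4)cc3)c(C)nc2cc1OC`: 1770 nM

Both were tested in a functional assay on HCC 2998 cells (Homo sapiens) for inhibition, read by sulforhodamine B assay, with a stated time of 48 h; on this read-out lower numbers stand for stronger inhibition of growth and higher numbers for weaker inhibition of growth. Compound 2 has the lowest of the two numbers; its nearest neighbour is compound 1, and the step between them is a 1.5-fold lower number from compound 1 to compound 2 (0.17 log units; within the scatter), so the two cannot be told apart on this read-out. Compound 3, `COc1cc2cc(Oc3ccc(NC(=O)Nc4ccc(Cl)c(Cl)c4)cc3)c(C)nc2cc1OC`, has not been tested yet. It differs from compound 2 in one place: chloro in place of trifluoromethyl on an aromatic carbon. Among the compounds with values here, only one measured step bears on this change, the one from compound 1 to compound 2, which added a chloro group on the same ring and stayed within the scatter. On that basis the swap of trifluoromethyl for chloro is expected to give no step beyond the scatter, in either direction. The expected step is a 1.1-fold higher number from compound 2 to compound 3 (0.05 log units; within the scatter). Compound 3 is therefore estimated at 2000 nM, with a range from 900 nM to 4500 nM.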

Compound 3, concentration for 50% growth inhibition: 5540 nM
The estimate for compound 3 lay 2.8-fold (0.44 log units) below the measured number, and the stated range ends below it.
By their numbers in this assay, from the lowest: compounds 2 and 1 (each within the scatter of the next); then compound 3.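

The earlier step put a chloro group on this ring and stayed within the scatter, which made the ring look tolerant of change. In this assay, the place ortho to a chloro group proves more sensitive: chloro in place of trifluoromethyl gives a 3.1-fold higher number from compound 2 to compound 3 (0.50 log units; beyond the scatter), a modest step but a real one, and the 3,4-dichlorophenyl group also differs from the 3-(trifluoromethyl)phenyl group, with a 2.1-fold higher number from compound 1 to compound 3 (0.33 log units; beyond the scatter). Nothing available on these compounds explains why trifluoromethyl gives the lower number here.

Going by these compounds, it remains open how other groups at this place would compare, such as a methyl, a methoxy or a nitrile. On these data alone, it is also open whether the swap of trifluoromethyl for chloro would give a similar step on a ring without the neighbouring chloro group.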